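From Compound 2 to Compound 3 in a Modulator Series

The compounds below may be only part of what the source reports. "The series", "measured", "known", "first", "only" and "open" are said of these compounds alone.

Of the compounds shown here, two have been measured in an assay on HEK293 cells for positive allosteric modulation of metabotropic glutamate receptor 2 (Rattus norvegicus), read by thallium flux; a higher number here means a larger maximal response, a lower number a smaller maximal response. Compound 1 `O=C(O)c1cc(-c2cccc(COc3ccc4c(=O)n(C5CCC5)sc4c3)c2)ccc1Cl` gives 83% in this assay. Compound 2 `O=C(O)c1cc(-c2cccc(COc3ccc4c(=O)n(C5CCCC5)sc4c3)c2)ccc1F` gives 83.4% in this assay, a value that lies within the scatter of compound 1, so the two cannot be told apart on these numbers; compound 2 simply holds one of the two values seen so far.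

Compound 3 `Cc1ccc(C(=O)O)cc1-c1cccc(COc2ccc3c(=O)n(C4CCCC4)sc3c2)c1` has not yet been measured in this assay. It differs from compound 2 in one place: 5-carboxy-2-methylphenyl in place of 3-carboxy-4-fluorophenyl on an aromatic carbon. Among the compounds with values here, no measured pair in this set isolates a change of this kind, so the data offer no step to lean on. Given that compound 1 and compound 2 sit so close together in this assay, the step from compound 2 to compound 3 is expected to be modest, most likely a small drop or none beyond the scatter, as a number 5.4 percentage points lower from compound 2 to compound 3 (within the scatter). For compound 3 the estimated value in this assay is therefore 78%, with a range from 60% to 95%.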

Compound 3, largest response reached (reported as percent of maximum), in percent of the reference or control that the assay uses: 82.9%
Compound 3: the middle estimate sits 4.9 percentage points below what was measured, and the stated range covers the measured number.
By their numbers in this assay, from the lowest: compounds 3, 1 and 2 (each within the scatter of the next).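

In this assay, within the data shown here, 5-carboxy-2-methylphenyl in place of 3-carboxy-4-fluorophenyl on an aromatic carbon gives a number 0.5 percentage points lower from compound 2 to compound 3 (within the scatter), and this is the first step in the set that isolates a single change. It shows that, with the rest of compound 2 held fixed, this place accepts a ring carrying methyl instead of fluorine, with the carboxy group also numbered differently, without any difference that can be told from the scatter in this read-out. The earlier pair could not show this, as compound 1 and compound 2 differ in more than one place, and no evidence here explains why the two groups read alike.

This one step combines two differences in the group, so it cannot separate the exchange of fluorine for methyl from the different arrangement of the carboxy group and that substituent. It also leaves open whether a nitrile or a methoxy group on this ring, or a tetrazole in place of the carboxylic acid, would read the same in this assay.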